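The source may report more compounds than this note shows. Statements on the series, on what has been measured and on what is new or still open speak of the compounds shown alone.

In a functional assay on MCF7 cells (Homo sapiens) for inhibition, read by MTT assay (on this read-out lower numbers stand for stronger inhibition of growth and higher numbers for weaker inhibition of growth), compound 1 `CC1=C(/C=C/C(C)=C/C=C/C(C)=C\C(=O)Nc2ccccc2)C(C)(C)CCC1n1ccnc1` gives 1900 nM and compound 2 `CC1=C(/C=C/C(C)=C/C=C/C(C)=C\C(=O)Nc2ccc(O)cc2)C(C)(C)CCC1n1ccnc1` gives 1990 nM, so compound 2 stands level with compound 1, within the scatter of repeat measurements. Compound 3 `CC1=C(/C=C/C(C)=C/C=C/C(C)=C\C(=O)NCc2cccc(F)c2)C(C)(C)CCC1n1ccnc1` carries 3-fluorobenzyl in place of 4-hydroxyphenyl on an amide-type nitrogen. Among the compounds with values here, the only measured step, hydroxy in place of hydrogen on an aromatic carbon, was small: a 1.0-fold higher number from compound 1 to compound 2 (0.02 log units; within the scatter). It does not test this swap, so it offers weak guidance and the range stays wide. The expected change in this assay is a 1.0-fold lower number from compound 2 to compound 3 (0.02 log units; within the scatter), with no step beyond the scatter and no favoured direction. Compound 3 is estimated at 1900 nM, with an expected range of 700 nM to 5000 nM.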

Compound 3, concentration for 50% growth inhibition: 1810 nM
Compound 3: the middle estimate sits 1.0-fold (0.02 log units) above what was measured; measured number inside the range.
By their numbers in this assay, from the lowest: compounds 3, 1 and 2 (each within the scatter of the next).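

Putting 3-fluorobenzyl in place of 4-hydroxyphenyl on the amide-type nitrogen gives a 1.1-fold lower number from compound 2 to compound 3 (0.04 log units; within the scatter) in this assay, and putting it in place of phenyl gives a 1.0-fold lower number from compound 1 to compound 3 (0.02 log units; within the scatter). Across these three compounds, then, this position tolerates a different ring substituent, and a group with 0 hydrogen-bond donors, without the number leaving the scatter. Nothing available explains why the number holds steady. Still open, from the compounds shown here alone, is whether a carboxylic acid, an amine or a longer chain on this nitrogen would shift the number.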